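Terminal acetamide to aldehyde on a long chain

The source may hold more compounds than are shown below. What is called first, only, known or untested is meant among the compounds shown, and "the series" means these compounds.

Compound 1 `CCCCCCCCC(O)CCCCCC/C=C1\CC(CO)(COC(=O)C(C)(C)C)OC1=O` — a limit, > 10 ug/mL, in a functional assay on SK-MEL-5 cells (Homo sapiens) for antiproliferative activity; a lower number here means a stronger inhibitor of growth, a higher number a weaker inhibitor of growth.
Compound 2 `CC(=O)NCCCCCCCCCCCCCCC/C=C1\CC(CO)(COC(=O)C(C)(C)C)OC1=O` — a limit, > 10 ug/mL, in this assay.

Compound 2 stands at a limit of this assay rather than at a number: the measurement of compound 2 stops at > 10 ug/mL. Going by the values given here, the same holds across the whole set, since both measured values sit at the limit of > 10 ug/mL in this assay, at which 2 of the 2 values shown sit, so no measured step between two compounds exists here and nothing yet separates one compound from the other in this assay.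

Compound 3 `CC(C)(C)C(=O)OCC1(CO)C/C(=C\CCCCCCCCCCCCCCC=O)C(=O)O1` is the next candidate. It differs from compound 2 in a single place: formyl in place of acetamidomethyl on a saturated chain carbon, ten or more bonds along the chain from a double-bonded chain carbon. Among the compounds with values here, the change sits far out on the saturated chain, and no measured pair shows what such a change does in this assay, so the expectation for compound 3 rests on the two limits alone.

Compound 3 is therefore expected to give about 15 ug/mL in this assay, most likely again as a limit, with a range from 5 ug/mL to 40 ug/mL. The step this estimate implies, a step that the limit leaves unreadable from compound 2 to compound 3, is expected to lie within the scatter rather than beyond it.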

Compound 3, concentration for 50% growth inhibition: > 10 ug/mL
Compound 3 ended at the assay's limit; the forecaster's own chance of this, stated with the estimate: 70%; the middle value lies beyond the limit too.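

In this assay, going by these compounds alone, compound 3 also stops at a limit, > 10 ug/mL, so no step from compound 1 or compound 2 to compound 3 can be read: the limit of > 10 ug/mL in this assay, at which 3 of the 3 values shown sit. The compounds shown leave open how far each lies past that limit, and whether the 1-hydroxynonyl, acetamidomethyl or formyl group changes growth inhibition at all.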